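A few compounds are considered here, and "the series" means these few. Any claim that something is new, unique, unknown or untested is made for them only; others in the source may bear on it.

In a functional assay on MCF7 cells (Homo sapiens) for antiproliferative activity, read by MTT assay, with a stated time of 72 h (a lower number here means a stronger inhibitor, a higher number a weaker inhibitor), compound 1 (`COc1cc(-n2cnc3ccc(-c4cccc(Cl)c4)cc32)cc(OC)c1OC`) gives 3120 nM and compound 2 (`COc1cc(-n2cnc3ccc(-c4cccc(F)c4)cc32)cc(OC)c1OC`) gives 2350 nM. Within the data shown here, these are the only two numbers available, and they cannot be told apart: the single measured step, a 1.3-fold lower number from compound 1 to compound 2 (0.12 log units; within the scatter), comes with fluoro in place of chloro on an aromatic carbon. Compound 2 therefore stands level with compound 1 in this assay, with no clear separation on either side.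

Compound 3 (`COc1ccc(-c2ccc3ncn(-c4cc(OC)c(OC)c(OC)c4)c3c2)cc1`) has not yet been measured. It differs from compound 2 in one place: 4-methoxyphenyl in place of 3-fluorophenyl on an aromatic carbon. In words, 4-methoxyphenyl stands in place of 3-fluorophenyl on an aromatic carbon. Among the measured compounds shown here, the one measured step bears on this change only loosely, since it exchanges one substituent on the aryl group and no measured compound carries 4-methoxyphenyl. The data thus offer no direct guide to direction, and a shift beyond the scatter is not expected in this assay. The expected step is a 1.2-fold lower number from compound 2 to compound 3 (0.07 log units; within the scatter). Compound 3 is estimated at 2000 nM, with an expected range of 550 nM to 7500 nM.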

Compound 3, half-maximal inhibitory concentration: 210 nM
For compound 3 the middle estimate is 9.5-fold (0.98 log units) above the measured one, and the stated range ends above it.
By their numbers in this assay, from the lowest: compound 3; then compounds 2 and 1 (each within the scatter of the next).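

The aryl group at this position matters far more than the earlier pair suggested. In this assay, the exchange of fluoro and chloro stayed within the scatter (a 1.3-fold lower number from compound 1 to compound 2 (0.12 log units; within the scatter)), whereas 4-methoxyphenyl in place of 3-fluorophenyl gives a large step (an 11-fold lower number from compound 2 to compound 3 (1.05 log units; beyond the scatter)), and 4-methoxyphenyl in place of 3-chlorophenyl gives one of similar scale (a 15-fold lower number from compound 1 to compound 3 (1.17 log units; beyond the scatter)). The position on the aromatic carbon of the fused system is therefore not indifferent to what it carries, although this change replaces the substituent, moves it from the 3-position to the 4-position of the phenyl ring and brings in a hydrogen-bond acceptor all at once, and nothing available accounts for the size of the step.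

Whether the gain follows the methoxy group or the 4-position stays open: no compound shown carries 3-methoxyphenyl or 4-fluorophenyl, which would separate the two. Also open, from the compounds shown here alone, is how this position would respond to a longer chain such as 4-ethoxyphenyl, or to an amine on the phenyl ring.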